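Swapping Trifluoromethyl for Chloro in Compound 3

This account rests on a few compounds, and the source may have more. Where it says the series, first, only, none or still open, it means among the compounds named here.

In a functional assay on HCT-116 cells (Homo sapiens) for antiproliferative activity, read by MTT assay, with a stated time of 24 h (on this read-out higher numbers stand for weaker inhibition and lower numbers for stronger inhibition), compound 3 `COc1cc(OC)c(-c2coc3cc(OCc4ccccc4C(F)(F)F)ccc3c2=O)cc1OC` gives 4760 nM. That value lies within the scatter of compound 2 `COc1cc(OC)c(-c2coc3cc(OCc4ccccc4F)ccc3c2=O)cc1OC`, which gives 2900 nM. Compound 1 `COc1cc(OC)c(-c2coc3cc(OCC(=O)c4cccc(C(F)(F)F)c4)ccc3c2=O)cc1OC` gives only a limit of the assay, > 10000 nM.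

The unmeasured compound 4 `COc1cc(OC)c(-c2coc3cc(OCc4ccccc4Cl)ccc3c2=O)cc1OC` keeps the shared core and alters one group of compound 3: chloro in place of trifluoromethyl on an aromatic carbon, ortho to a large group (chloro in place of trifluoromethyl on an aromatic carbon).

Two of the measured steps are large enough to stand out, an at least 3.4-fold lower number from compound 1 to compound 2 (0.53 log units; beyond the scatter) and an at least 2.1-fold lower number from compound 1 to compound 3 (0.32 log units; beyond the scatter). Both remove the (3-(trifluoromethyl)phenyl)carbonyl group, a much bigger change than the one considered here, so they offer little guidance. The closer comparison is a 1.6-fold higher number from compound 2 to compound 3 (0.22 log units; within the scatter), where trifluoromethyl takes the place of fluoro on an aromatic carbon. Within the data shown here, that single step is the only measured exchange of this kind, so no shift beyond the scatter is expected in this assay, in either direction. The expected step is a 1.3-fold lower number from compound 3 to compound 4 (0.11 log units; within the scatter). Compound 4 is estimated at 3700 nM, with an expected range of 1600 nM to 8000 nM.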

Compound 4, half-maximal inhibitory concentration: 2450 nM
Beside the measured number, compound 4's estimate is 1.5-fold (0.18 log units) above it; low and high end bracket the measured number.
By their numbers in this assay, from the lowest: compounds 4, 2 and 3 (each within the scatter of the next). At a limit, above all of these: compound 1.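

In this assay, chloro in place of trifluoromethyl gives a 1.9-fold lower number from compound 3 to compound 4 (0.29 log units; within the scatter), and chloro in place of fluoro gives a 1.2-fold lower number from compound 2 to compound 4 (0.07 log units; within the scatter). This place on the aromatic ring, ortho to a large group, has now carried three different groups, among them chloro with 1 heavy atom and trifluoromethyl with 4, and compounds 2, 3 and 4 all remain within the scatter of one another, so this assay does not separate these three groups. The only new step beyond the scatter, an at least 4.0-fold lower number from compound 1 to compound 4 (0.61 log units; beyond the scatter), exchanges a whole group, 2-chlorophenyl in place of (3-(trifluoromethyl)phenyl)carbonyl, and it starts from a limit of the assay rather than a number, so its true size stays unknown: the limit of > 10000 nM in this assay, at which 1 of the 4 values shown sits.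

The compounds shown leave open whether a group of another kind at this place, such as a methoxy group, an amine or a carboxylic acid, would shift the number beyond the scatter. They also leave open whether chloro, fluoro and trifluoromethyl would stay this close to one another on a different carbon of the same ring.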